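Working notes on compounds 1 to 4

A few compounds are considered here, and "the series" means these few. Any claim that something is new, unique, unknown or untested is made for them only; others in the source may bear on it.

The series is read in a functional assay on U-937 cells (Homo sapiens) for cytotoxicity, read by MTT assay, with a stated time of 48 h; on this read-out lower numbers stand for stronger inhibition and higher numbers for weaker inhibition. Compound 1 `Fc1cccc(-c2nc(Nc3ccccc3F)c3cc(F)ccc3n2)c1` sits at a limit of the assay, > 50000 nM. Compound 2 `Fc1cccc(-c2nc(Nc3ccc(Cl)cc3)c3cc(F)ccc3n2)c1` gives 32700 nM in this assay. Compound 3 `Fc1cccc(-c2nc(Nc3ccc(Br)cc3)c3cc(F)ccc3n2)c1` also sits at a limit, > 50000 nM. Two of the three results thus share the same point, (the limit of > 50000 nM in this assay, at which 2 of the 3 values shown sit), so compound 3 stands at the weak end of what the assay reports rather than at a number.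

Among the measured steps, an at least 1.5-fold lower number from compound 1 to compound 2 (0.18 log units; that floor lies within the scatter) and an at least 1.5-fold higher number from compound 2 to compound 3 (0.18 log units; that floor lies within the scatter) are each read against a limit, while a step that the two limits leave unreadable from compound 1 to compound 3 cannot be read at all.

Compound 4 `Oc1cccc(Nc2nc(-c3cccc(F)c3)nc3ccc(F)cc23)c1` differs from compound 3 by 3-hydroxyphenyl in place of 4-bromophenyl on a nitrogen on an aromatic ring. Among the compounds with values here, no measured step exchanges a bromo or any halogen for a hydroxy group, so none bears directly on this change; the ring on the nitrogen has been varied in each of the measured compounds and every result stays at or near the weak end. The expected step is therefore an at least 1.1-fold lower number from compound 3 to compound 4 (0.04 log units; that floor lies within the scatter), with no direction claimed beyond the scatter. Compound 4 is estimated at 45000 nM, between 15000 nM and 150000 nM.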

Compound 4, half-maximal inhibitory concentration: > 50000 nM
Compound 4: no number, only a limit; the forecaster's own chance of this, stated with the estimate: 55%; middle value at least 1.1-fold (0.04 log units) away from the limit.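

Compound 4 is a limit in this assay (> 50000 nM), so 3-hydroxyphenyl on the nitrogen, with its hydrogen-bond donor and acceptor, gives no readable number where 4-bromophenyl gave none either. Within the data shown here, the only readable step is an at least 1.5-fold higher number from compound 2 to compound 4 (0.18 log units; that floor lies within the scatter) and it is a floor; the steps joining compound 4 to compound 1 and compound 3 cannot be read. A hydroxy-bearing ring now joins the halogen-bearing rings on this nitrogen, and the results still gather at one point: the limit of > 50000 nM in this assay, at which 3 of the 4 values shown sit.

As far as these compounds go, how far compound 4 and the other compounds at the limit lie from compound 2 stays open. Also open, from the compounds shown here alone, is what an amine or a carboxylic acid on this ring would give in this assay, and whether any group here reaches a clearly lower number.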